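Notes on a thioether series: the chloro step to compound 4

The compounds below may be only part of what the source reports. "The series", "measured", "known", "first", "only" and "open" are said of these compounds alone.

Measured compounds:
compound 1, `CC1=C(C(=O)Nc2ccc(Br)cc2)C(c2ccc(Cl)cc2Cl)N=C(SCc2ccc(F)cc2)N1`; in a functional assay on the whole organism (artery, strain albino) with Rattus norvegicus as the target, with a stated time of 300 min, at a dose of 10 mg/kg by the oral route (a lower number here means less inhibition, a higher number more inhibition at the dose given (going by the name of the read-out)), compound 1 gives 38.5%
compound 2, `COc1ccc(C2N=C(SCc3ccccc3)NC(C)=C2C(=O)Nc2ccc(Br)cc2)cc1`; compound 2 gives 16.4%
compound 3, `CC1=C(C(=O)Nc2ccc([N+](=O)[O-])cc2)C(c2ccc(Br)cc2)N=C(SCc2ccccc2)N1`; compound 3 gives 29.7%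

Compound 3 stands second highest of the three numbers in this assay. Its nearest neighbour is compound 1, whose number is higher, but the gap between compound 3 and compound 1 lies within the scatter, so no order between them can be read. Compound 2 lies lower than compound 3 by a margin beyond the scatter. Compound 3 differs from compound 1 and from compound 2 in more than one place, so these gaps cannot be assigned to any single change.

Compound 4 is `CC1=C(C(=O)Nc2ccc([N+](=O)[O-])cc2)C(c2ccc(Br)cc2)N=C(SCc2ccc(Cl)cc2)N1`. It differs from compound 3 in one place: chloro in place of hydrogen on an aromatic carbon. Among the compounds with values here, no pair of measured compounds differs in one place, so no comparable step is available. The step of a number 3.3 percentage points higher from compound 3 to compound 4 (within the scatter) is expected to be small, upward if anything, and not beyond the scatter. Compound 4 is estimated at 33%, with an expected range from 18% to 48%.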

Compound 4, a percentage reported as inhibition, in the whole organism at one dose (the size of the read-out at that dose, not a potency): 37.9%
For compound 4 the middle estimate is 4.9 percentage points below the measured one; measured number inside the range.
By their numbers in this assay, from the lowest: compound 2; then compounds 3, 4 and 1 (each within the scatter of the next).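

In this assay, within the data shown here, the change from benzylsulfanyl to (4-chlorobenzyl)sulfanyl gives a number 8.2 percentage points higher from compound 3 to compound 4 (within the scatter) and is the first difference that can be tied to one place. At this position, on this background, chloro in place of hydrogen leaves the read-out at the dose given within the scatter, so no order can be read between the two compounds and the position accepts the chloro group without a shift that can be resolved. No measured property of these compounds bears on this step.

As far as these compounds go, whether an amine or a carboxylic acid at the same position would move the read-out beyond the scatter stays open. Also open, from the compounds shown here alone, is whether the chloro step would stay as small on the other groups carried by compound 2 .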